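Thiadiazole for oxadiazole on the thioether of compound 3

The source may hold more compounds than are shown below. What is called first, only, known or untested is meant among the compounds shown, and "the series" means these compounds.

In a functional assay on HEp-2 cells (Homo sapiens) for cytotoxicity, read by MTT assay, with a stated time of 72 h (on this read-out lower numbers stand for stronger inhibition and higher numbers for weaker inhibition), compound 3 `Cc1nnc(SCc2coc3ccccc3c2=O)o1` gives 3800 nM. For the measured compounds named here, the only other number in this assay comes from compound 1 `Cc1nnc(SCc2coc3ccc(Cl)cc3c2=O)o1`, which gives 6400 nM; the step of a 1.7-fold lower number from compound 1 to compound 3 (0.23 log units; within the scatter) means the two are not told apart by this read-out. Compound 2 `Cc1cc(C)n2nc(SCc3nnc(SCc4cc(=O)c5ccccc5o4)o3)nc2n1` gives > 25000 nM, which is a limit of this assay and not a number. That limit is the point (the limit of > 25000 nM in this assay, at which 1 of the 3 values shown sits).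

Compound 4 `Cc1nnc(SCc2coc3ccccc3c2=O)s1` differs from compound 3 in one place: 5-methyl-1,3,4-thiadiazol-2-yl in place of 5-methyl-1,3,4-oxadiazol-2-yl on a sulfur. Going by the values given here, the single measured step, from compound 1 to compound 3, changes a substituent on the aromatic carbon of the shared core and leaves the thioether and the five-membered ring untouched, so it says nothing about swapping one five-membered aromatic ring for another. Among the compounds with values here, no measured pair changes that ring. With nothing in the data pointing either way, the change from compound 3 to compound 4 is expected to give no step beyond the scatter, in either direction, as a 1.1-fold lower number from compound 3 to compound 4 (0.04 log units; within the scatter).

Compound 4 is therefore estimated at 3500 nM in this assay, with a range from 1200 nM to 12000 nM to allow for the absence of any measured step of this kind.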

Compound 4, half-maximal inhibitory concentration: 2900 nM
Estimate against measurement, compound 4: 1.2-fold (0.08 log units) above; low and high end bracket the measured number.
By their numbers in this assay, from the lowest: compounds 4, 3 and 1 (each within the scatter of the next, the first and the last beyond it). At a limit, above all of these: compound 2.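

In this assay, for the compounds shown here, the only measured change of the five-membered aromatic ring on the sulfur gives a 1.3-fold lower number from compound 3 to compound 4 (0.12 log units; within the scatter) and so does not tell 5-methyl-1,3,4-thiadiazol-2-yl from 5-methyl-1,3,4-oxadiazol-2-yl on this read-out. Going by these compounds alone, the earlier step of a 1.7-fold lower number from compound 1 to compound 3 (0.23 log units; within the scatter) concerned a chloro on an aromatic carbon of the shared core and left this place untouched, so the pair of compound 3 and compound 4 is the first reading on the ring itself, with sulfur in place of oxygen in that ring and the rest of the structure the same. Nothing on hand bears on this step or offers a cause for it.

From the compounds shown here alone, whether an amine or a carboxylic acid in place of the methyl on the five-membered ring, or a longer chain in place of that methyl, would move the number beyond the scatter stays open. Within the data shown here, compound 2 gives > 25000 nM as a limit and not a number, and it offers no step to set beside this one.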